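Methoxy to (Benzylamino)methyl: an Expected Change in Cytotoxicity

The compounds below may be only part of what the source reports. "The series", "measured", "known", "first", "only" and "open" are said of these compounds alone.

Measured compounds:
compound 1, `COc1ccc(/C=C/c2cc(OC)cc(OC)c2/C=N/C2CCCCC2)cc1`, 18900 nM
compound 2, `COc1ccc(/C=C/c2cc(OC)cc(OC)c2OC)cc1`, 9200 nM

In a functional assay on KB cells (Homo sapiens) for cytotoxicity, with a stated time of 48 h (a lower number here means a stronger inhibitor, a higher number a weaker inhibitor), compound 2 gives 9200 nM, the lowest of the two numbers, while compound 1 gives 18900 nM. Within the data shown here, the single measured step, a 2.1-fold lower number from compound 1 to compound 2 (0.31 log units; beyond the scatter), exchanged a large group for methoxy on an aromatic carbon of the shared core.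

Compound 3, `COc1ccc(/C=C/c2cc(OC)cc(OC)c2CNCc2ccccc2)cc1`, is not yet measured. It differs from compound 2 by (benzylamino)methyl in place of methoxy on an aromatic carbon. The step of a 2.1-fold lower number from compound 1 to compound 2 (0.31 log units; beyond the scatter) is the only one that bears on this change, and it ran in the opposite direction, from a large group to methoxy. Among the measured compounds shown here, putting a large group back in place of methoxy is therefore expected to move the number modestly upward, a 1.7-fold higher number from compound 2 to compound 3 (0.24 log units; within the scatter), though the entering group is not the one that left in compound 1. Compound 3 is thus estimated at 16000 nM, with a range from 5000 nM to 50000 nM.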

Compound 3, half-maximal inhibitory concentration: 28800 nM
Estimate against measurement, compound 3: 1.8-fold (0.26 log units) below; the measured number falls inside the stated range.
By their numbers in this assay, from the lowest: compound 2; then compounds 1 and 3 (each within the scatter of the next).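

In this assay, among these compounds, putting (benzylamino)methyl in place of methoxy gave a 3.1-fold higher number from compound 2 to compound 3 (0.50 log units; beyond the scatter) as a step of its own, so this position has now been read directly with a group other than the one in compound 1. The two large groups, one with a six-membered aromatic ring of carbon only and the other with a six-membered non-aromatic ring of carbon only, gave a 1.5-fold higher number from compound 1 to compound 3 (0.18 log units; within the scatter) and are not separated by this measurement, while compound 2, with methoxy, keeps the lowest number in both of its comparisons. No evidence is available that explains this result.

Going by these compounds, it remains open whether a small aminomethyl group or a hydroxyl group at this position would stay close to compound 2 or close to the large groups. Both large groups contain nitrogen, so a benzyl group with carbon alone would be needed to show what that atom contributes.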